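A few compounds are considered here, and "the series" means these few. Any claim that something is new, unique, unknown or untested is made for them only; others in the source may bear on it.

This account follows a single change, from compound 1 to compound 4. Compound 1, `Cc1nc(S)n(Nc2cccc(Cl)c2)c1-c1ccc(Br)cc1`, is the starting point: in a functional assay on MT4 cells (Homo sapiens) for cytotoxicity (a higher number here means that more compound is tolerated, a lower number that less compound is tolerated), compound 1 gives 33200 nM, the lowest of the three numbers available. Compound 2, `COc1ccc(-c2c(C)nc(S)n2Nc2cccc(Cl)c2)cc1`, gives 38700 nM, a move described by a 1.2-fold higher number from compound 1 to compound 2 (0.07 log units; within the scatter). Compound 3, `COC(=O)C1C(C)N=CN1Nc1cccc(Cl)c1`, gives 107000 nM, which stands beyond the scatter from compound 1. Compound 4, `Cc1nc(S)n(Nc2cccc(Cl)c2)c1-c1cccc(Br)c1`, differs from compound 1 as follows: 3-bromophenyl in place of 4-bromophenyl on an aromatic carbon. Going by the values given here, no measured step shifts a bromine around its ring, and the only step recorded, a 1.2-fold higher number from compound 1 to compound 2 (0.07 log units; within the scatter), stays within the scatter. With nothing pointing either way, the step of a 1.0-fold lower number from compound 1 to compound 4 (0.00 log units; within the scatter) is expected to stay within the scatter as well. Compound 4 is therefore estimated at 33000 nM, with a range from 15000 nM to 72000 nM.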

Compound 4, half-maximal cytotoxic concentration: 44000 nM
For compound 4 the middle estimate is 1.3-fold (0.12 log units) below the measured one; low and high end bracket the measured number.
By their numbers in this assay, from the lowest: compounds 1, 2 and 4 (each within the scatter of the next); then compound 3.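

In this assay, 3-bromophenyl in place of 4-bromophenyl gives a 1.3-fold higher number from compound 1 to compound 4 (0.12 log units; within the scatter), so for this pair, moving the bromine around its ring leaves the cytotoxic concentration indistinguishable from the scatter. Going by these compounds alone, this is the first look at the bromine's place on that ring, whereas the earlier step changed bromo itself to methoxy. No supporting data bear on this result. Still open, going by these compounds, is whether a ring carrying an amine or a carboxylic acid in place of the bromine would keep the number this close to that of compound 1.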